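Tolerated Concentrations of Compound 3 and Compound 4

The source may hold more compounds than are shown below. What is called first, only, known or untested is meant among the compounds shown, and "the series" means these compounds.

Measured so far:
Compound 1 `CCCS(=O)(=O)Nc1ccc2c(c1)S(=O)(=O)N=C(c1c(O)c(-c3cccs3)nn(CCC(C)C)c1=O)N2`, in an ADME assay on Huh-7 cells (Homo sapiens) for cytotoxicity, with a stated time of 72 h (a lower number here means that less compound is tolerated, a higher number that more compound is tolerated), reaches a limit of > 1000 nM.
Compound 2 `CC(C)CCc1nn(CCC(C)C)c(=O)c(C2=NS(=O)(=O)c3cc(NS(C)(=O)=O)ccc3N2)c1O`, in this assay, reaches a limit of > 33000 nM.
Compound 3 `CCC(C)CCn1nc(-c2cccs2)c(O)c(C2=NS(=O)(=O)c3cc(NS(C)(=O)=O)ccc3N2)c1=O`, in this assay, reaches a limit of > 1000 nM.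

None of these three readings is a number; each is a limit of this assay, reached without a half-maximal cytotoxic concentration being found. Compound 3 stands at the limit of > 1000 nM in this assay, at which 2 of the 3 values shown sit. Compound 1 stands at the same limit. Compound 2 stands at the limit of > 33000 nM in this assay, at which 1 of the 3 values shown sits. All three readings are limits. Among the compounds with values here, no step between measured compounds can be computed, and nothing is known about how much any one structural change moves tolerance in this assay.

Compound 4 `CS(=O)(=O)Nc1ccc2c(c1)S(=O)(=O)N=C(c1c(O)c(-c3cccs3)nn(CC3(C(F)(F)F)CCC3)c1=O)N2` has not yet been measured. It differs from compound 3 in one place: 1-(trifluoromethyl)cyclobutyl in place of 2-methylbutyl on a saturated chain carbon bound to an aromatic nitrogen. Within the data shown here, with no measured step to lean on, the size of the change in tolerance is open. The expectation is that the step from compound 3 to compound 4 in this assay amounts to a step that the limit leaves unreadable from compound 3 to compound 4, none beyond the scatter. Compound 4 is expected to give about 3000 nM in this assay, within a range from 800 nM to 30000 nM, and most likely to be reported again as a limit rather than a number.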

Compound 4, half-maximal cytotoxic concentration: > 1000 nM
Compound 4: only a limit was reported (the forecaster's own chance of this, stated with the estimate: 70%); the middle value is on the limit's open side.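

In this assay compound 4 gives > 1000 nM, a limit and not a number. Within the data shown here, compound 3 gives > 1000 nM, also a limit, so no step between compound 3 and compound 4 can be read. The compounds shown leave open whether 1-(trifluoromethyl)cyclobutyl in place of 2-methylbutyl changes tolerance at all, and where any half-maximal cytotoxic concentration lies.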